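Piperidine replaces methylpiperazine on the aromatic-nitrogen chain

The source may report more compounds than this note shows. Statements on the series, on what has been measured and on what is new or still open speak of the compounds shown alone.

Notes on the series. Of the compounds shown here, three have been measured in a functional assay on MDA-MB-231 cells (Homo sapiens) for cytotoxicity, read by MTT assay, with a stated time of 72 h; on this read-out higher numbers stand for weaker inhibition and lower numbers for stronger inhibition. Compound 1 `O=C1c2c[n+]([O-])c3ccccc3c2C(=O)c2c1c1ccccc1n2Cc1cn([C@H]2C[C@H](O)[C@@H](CO)O2)nn1` gives 580 nM in this assay. Compound 2 `CC1(C)O[C@@H](CO)[C@H](Cn2cc(Cn3c4c(c5ccccc53)C(=O)c3c[n+]([O-])c5ccccc5c3C4=O)nn2)O1` gives 680 nM. Among the measured compounds shown here, the one single-point step so far is a 1.2-fold higher number from compound 1 to compound 2 (0.07 log units; within the scatter), a change on an aromatic nitrogen at the other end of the shared core. Compound 3 `CN1CCN(CCCn2c3c(c4ccccc42)C(=O)c2c[n+]([O-])c4ccccc4c2C3=O)CC1` gives 390 nM, the lowest of the three numbers, but its gaps to compound 1 and to compound 2 are both within the scatter, so no order among the three is claimed.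

Compound 4 `O=C1c2c[n+]([O-])c3ccccc3c2C(=O)c2c1c1ccccc1n2CCN1CCCCC1` differs from compound 3 by piperidin-1-yl in place of (4-methylpiperazin-1-yl)methyl on a saturated chain carbon, two bonds along the chain from an aromatic nitrogen. For the measured compounds named here, no measured step in this assay touches the chain on the indole-type nitrogen of the core; the step from compound 1 to compound 2 concerns a different position and was itself within the scatter. The data therefore give no direction for this change. The step from compound 3 to compound 4 is expected to be a 1.2-fold higher number from compound 3 to compound 4 (0.06 log units; within the scatter), no more than the scatter. Compound 4 is estimated at 450 nM, with a range from 200 nM to 1000 nM.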

Compound 4, half-maximal inhibitory concentration: 1050 nM
For compound 4 the middle estimate is 2.3-fold (0.37 log units) below the measured one; measured number above the stated range.
By their numbers in this assay, from the lowest: compounds 3, 1, 2 and 4 (each within the scatter of the next, the first and the last beyond it).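

In this assay the series now holds its first step beyond the scatter, a 2.7-fold higher number from compound 3 to compound 4 (0.43 log units; beyond the scatter), so the chain on the aromatic nitrogen is a place where a change can move the number, here modestly and towards weaker inhibition. The change is more than a swap of rings: cut one bond further out, it reads 3-(4-methylpiperazin-1-yl)propyl to 2-(piperidin-1-yl)ethyl, so ring and chain differ together in this single step. No supporting data on the compounds bear on this result.

With one step at this position, the ring and the chain cannot be separated. As far as these compounds go, a 2-(4-methylpiperazin-1-yl)ethyl chain, or piperidin-1-yl on a propyl chain, would divide the two, and whether a morpholine ring on either chain follows the same direction remains open.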